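This account rests on a few compounds, and the source may have more. Where it says the series, first, only, none or still open, it means among the compounds named here.

Compound 1 `Clc1ccc(COc2ccc(CNCc3ccncc3)cc2)cc1`: 4000 nM
Compound 2 `COc1cc(CNCc2ccncc2)ccc1OCc1ccc(C)cc1`: 5000 nM
Compound 3 `COc1cc(CNCCNc2ccnc3cc(Cl)ccc23)ccc1OCc1ccc(Cl)nc1`: 2700 nM

All three values come from a functional assay on HeLa cells (Homo sapiens) for inhibition, with a stated time of 72 h; on this read-out higher numbers stand for an effect only at larger amounts of compound and lower numbers for an effect already at smaller amounts. Compound 2 stands level with the other two, since its value lies within the usual scatter of both. Compound 4 `COc1cc(CNCc2ccncc2)ccc1OCc1cccc(F)c1` is still unmeasured. It differs from compound 2 in one place: 3-fluorophenyl in place of 4-methylphenyl on a saturated chain carbon bound to an oxygen on an aromatic ring, with 3-fluorophenyl in place of 4-methylphenyl on a saturated chain carbon bound to an oxygen on an aromatic ring. For the measured compounds named here, no measured pair isolates this swap, so the expectation rests on how close the values are, with compound 2 at 5000 nM and compound 1 at 4000 nM. The expected change, a 1.2-fold lower number from compound 2 to compound 4 (0.08 log units; within the scatter), stays within the scatter. For compound 4 the estimated value is 4200 nM, with an expected range of 1800 nM to 10000 nM.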

Compound 4, half-maximal effective concentration: 4800 nM
Beside the measured number, compound 4's estimate is 1.1-fold (0.06 log units) below it; low and high end bracket the measured number.
By their numbers in this assay, from the lowest: compounds 3, 1, 4 and 2 (each within the scatter of the next).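

For the compounds shown here, this is the first pair among the compounds that isolates a single change. In this assay, putting 3-fluorophenyl in place of 4-methylphenyl on a saturated chain carbon bound to an oxygen on an aromatic ring gives (a 1.0-fold lower number from compound 2 to compound 4 (0.02 log units; within the scatter)), so this read-out does not tell these two groups apart here. No measurement at hand offers a reason for this result.

Still open, on these data alone, is whether a carboxylic acid or an amine on this phenyl ring would move the number beyond the scatter. Also open, as far as these compounds go, is how 4-fluorophenyl would read here.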